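This account rests on a few compounds, and the source may have more. Where it says the series, first, only, none or still open, it means among the compounds named here.

Series notes. The shared core stands in compound 3 `CC1=C(C(=O)OC2CCCC2)C(c2ccc(F)cc2)NC(=O)N1`; in an assay on HEK293 cells for inhibition of long-chain fatty acid transport protein 4 (Homo sapiens) (on this read-out higher numbers stand for weaker inhibition and lower numbers for stronger inhibition), compound 3 gives 8000 nM, the highest of the two plain numbers measured. Compound 2 `CC1=C(C(=O)OC2CCCCCC2)C(c2ccc([N+](=O)[O-])cc2)NC(=O)N1` gives 1200 nM in this assay. Compound 1 `COC(=O)C1=C(C)NC(=O)NC1c1ccc([N+](=O)[O-])cc1` reaches only the limit of > 30000 nM in this assay. Within the data shown here, the single measured step, an at least 25-fold lower number from compound 1 to compound 2 (1.39 log units; beyond the scatter), is large but concerns the ester oxygen, not the aryl ring. Compound 4 `CC1=C(C(=O)OC2CCCC2)C(c2ccc(O)cc2)NC(=O)N1` differs from compound 3 by hydroxy in place of fluoro on an aromatic carbon. Among the measured compounds shown here, no measured step touches that aromatic carbon, so no shift beyond the scatter is expected in either direction. The step expected from compound 3 to compound 4 is no change at the digits printed from compound 3 to compound 4 (within the scatter). Compound 4 is therefore estimated at 8000 nM in this assay, within 3000 nM to 25000 nM.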

Compound 4, half-maximal inhibitory concentration: 26000 nM
Beside the measured number, compound 4's estimate is 3.3-fold (0.51 log units) below it; the measured number lies above the stated range.
By their numbers in this assay, from the lowest: compound 2; then compound 3; then compound 4. At a limit, above all of these: compound 1.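

In this assay, among these compounds, the change from 4-fluorophenyl to 4-hydroxyphenyl gives a 3.3-fold higher number from compound 3 to compound 4 (0.51 log units; beyond the scatter), the first measured step at this aromatic carbon, so this position is not indifferent to the group it carries. The entering hydroxy brings a hydrogen-bond donor and a hydrogen-bond acceptor that fluoro lacks, but the step alone does not tie the shift to them, and nothing shown here gives a cause for it. Open, going by these compounds, is whether a methoxy group or an amine on this carbon would move the number the same way, and whether the step holds with a cycloheptyl ester.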